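From 2,3-dimethylphenyl to 2-fluoro-5-methylphenyl

The compounds below may be only part of what the source reports. "The series", "measured", "known", "first", "only" and "open" are said of these compounds alone.

In a functional assay on KB cells (Homo sapiens) for antiproliferative activity, read by sulforhodamine B assay, with a stated time of 3 days (on this read-out lower numbers stand for an effect already at smaller amounts and higher numbers for an effect only at larger amounts of compound), compound 3 (`CCC1=C(O)c2c(oc(-c3cccc(C)c3C)cc2=O)C(CC)(CC)C1=O`) gives 3.1 uM, the lowest number of the three, against compound 2 (`CCC1=C(O)c2c(oc(-c3cc(C)c(O)c(C)c3)cc2=O)C(CC)(CC)C1=O`) at 18.3 uM and compound 1 (`CCC1=C(O)c2c(oc(-c3ccc(C)c(C)c3)cc2=O)C(CC)(CC)C1=O`) at 35.5 uM. Compound 4 (`CCC1=C(O)c2c(oc(-c3cc(C)ccc3F)cc2=O)C(CC)(CC)C1=O`) carries 2-fluoro-5-methylphenyl in place of 2,3-dimethylphenyl on an aromatic carbon. The nearest evidence is a 5.9-fold lower number from compound 2 to compound 3 (0.77 log units; beyond the scatter) and an 11-fold lower number from compound 1 to compound 3 (1.06 log units; beyond the scatter), both beyond the scatter, whereas a 1.9-fold lower number from compound 1 to compound 2 (0.29 log units; within the scatter) stays within it. Only the groups of compound 3 and compound 4 have a substituent numbered 2, so part of an 11-fold lower number from compound 1 to compound 3 (1.06 log units; beyond the scatter) may carry over. For the measured compounds named here, no measured step covers fluorine. A modest rise is expected, a 1.9-fold higher number from compound 3 to compound 4 (0.29 log units; within the scatter). The estimate for compound 4 is 6 uM, with an expected range of 2 uM to 18 uM.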

Compound 4, concentration for half-maximal effect: 47.3 uM
Estimate against measurement, compound 4: 7.9-fold (0.90 log units) below, and the stated range ends below it.
By their numbers in this assay, from the lowest: compound 3; then compounds 2, 1 and 4 (each within the scatter of the next, the first and the last beyond it).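

In this assay a substituent numbered 2 does not by itself keep the low number of compound 3, since a 15-fold higher number from compound 3 to compound 4 (1.18 log units; beyond the scatter) is a large step although both groups carry one. The modest 2.6-fold higher number from compound 2 to compound 4 (0.41 log units; beyond the scatter) and a 1.3-fold higher number from compound 1 to compound 4 (0.12 log units; within the scatter) within the scatter leave 2-fluoro-5-methylphenyl with no gain over either group. Nothing at hand accounts for this loss.

Fluorine and the methyl position change together here, so their separate shares cannot be read. 2,5-Dimethylphenyl or 2-fluoro-3-methylphenyl would separate them.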